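From Compound 2 to Compound 3: One Further Step

The source may report more compounds than this note shows. Statements on the series, on what has been measured and on what is new or still open speak of the compounds shown alone.

In a functional assay on A-431 cells (Homo sapiens) for inhibition, read by MTT assay, with a stated time of 72 h (a lower number here means a stronger inhibitor, a higher number a weaker inhibitor), compound 1 (`O=C(CCN=C=S)Nc1ccc2ncnc(Nc3cccc(Br)c3)c2c1`) gives 17100 nM. Among the compounds with values here, compound 2 (`O=C(CCCN=C=S)Nc1ccc2ncnc(Nc3cccc(Br)c3)c2c1`) gives 17100 nM, which leaves it level with compound 1 at the digits reported, and compound 1 is its only measured neighbour.

Compound 3 (`O=C(CCCCN=C=S)Nc1ccc2ncnc(Nc3cccc(Br)c3)c2c1`) has not yet been measured. It differs from compound 2 by a group of 4 heavy atoms (2 carbon, 1 nitrogen, 1 sulfur; no ring) in place of a group of 3 heavy atoms (1 carbon, 1 nitrogen, 1 sulfur; no ring), on a saturated chain carbon, three bonds along the chain from a carbonyl carbon. Within the data shown here, the closest precedent is the step of no change at the digits printed from compound 1 to compound 2 (within the scatter), which placed the same kind of group on a saturated chain carbon, two bonds along the chain from a carbonyl carbon. Among the measured compounds shown here, that step stayed within the scatter, and it is the only measured step that bears on the new change. A single pair shows no trend, so the expectation rests on thin evidence.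

No shift beyond the scatter is therefore expected in this assay, and no direction is favoured. The expected step of a 1.0-fold lower number from compound 2 to compound 3 (0.00 log units; within the scatter) is accordingly small. Compound 3 is estimated at 17000 nM, with an expected range of 8000 nM to 36000 nM.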

Compound 3, half-maximal inhibitory concentration: 16300 nM
Compound 3: the middle estimate sits 1.0-fold (0.02 log units) above what was measured; low and high end bracket the measured number.
By their numbers in this assay, from the lowest: compounds 3, 1 and 2 (each within the scatter of the next).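

In this assay, the group of 4 heavy atoms in place of the group of 3 heavy atoms, now three bonds along the chain from a carbonyl carbon, gives a 1.0-fold lower number from compound 2 to compound 3 (0.02 log units; within the scatter), so the change that stayed within the scatter at two bonds along the chain also stays within it at three. The comparison across both steps gives a 1.0-fold lower number from compound 1 to compound 3 (0.02 log units; within the scatter), which shows that the two small steps do not add up to a shift beyond the scatter, something a single pair could not show. Among these three compounds, chain length therefore leaves the number within the scatter, no compound goes against this, and no available evidence accounts for the result.

On these data alone, whether a still longer chain would stay within the scatter remains open, since these three chain lengths cannot show where such tolerance ends. As far as these compounds go, it is also open whether an amine or a carboxylic acid at the end of the chain, in place of the present group, would give a different number.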